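Removing a Large Group from Compound 2

The source may hold more compounds than are shown below. What is called first, only, known or untested is meant among the compounds shown, and "the series" means these compounds.

Compound 1 `CC1(C)OB(c2ccc(COc3cccc4ccc(C(=O)N5CCC(Oc6no[n+]([O-])c6S(=O)(=O)c6ccccc6)CC5)nc34)cc2)OC1(C)C` gives 34200 nM
Compound 2 `O=C(NCCCOc1no[n+]([O-])c1S(=O)(=O)c1ccccc1)c1ccc2cccc(OCc3ccc(B(O)O)cc3)c2n1` gives 15400 nM

Both values come from a functional assay on SW1990 cells (Homo sapiens) for cytotoxicity, read by MTT assay, with a stated time of 48 h, in the presence of a further agent that is not named here; a higher number here means a weaker inhibitor, a lower number a stronger inhibitor. Compound 2 has the lower number of the two, so it is the stronger inhibitor, and its gap to compound 1 lies beyond the usual scatter. Compound 3 `O=C(NCCCOc1no[n+]([O-])c1S(=O)(=O)c1ccccc1)c1ccc2cccc(O)c2n1` differs from compound 2 in one place, on an oxygen on an aromatic ring: a hydrogen atom in place of a group of 10 heavy atoms (7 carbon, 1 boron, 2 oxygen; one six-membered aromatic ring of carbon only), on an oxygen on an aromatic ring. For the measured compounds named here, no measured pair shows this change, so any forecast is uncertain. A moderate move toward a lower number is expected, although a change within the scatter remains possible. The estimated step is a 1.9-fold lower number from compound 2 to compound 3 (0.28 log units; within the scatter). Compound 3 is expected at 8000 nM, with an estimated range from 2500 nM to 25000 nM.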

Compound 3, half-maximal inhibitory concentration: 12100 nM
Compound 3: the middle estimate sits 1.5-fold (0.18 log units) below what was measured; the range from low to high includes it.
By their numbers in this assay, from the lowest: compounds 3 and 2 (each within the scatter of the next); then compound 1.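

In this assay, replacing the group of 10 heavy atoms on this oxygen with a hydrogen atom gives a 1.3-fold lower number from compound 2 to compound 3 (0.10 log units; within the scatter). For the compounds shown here, this is the first look at this position, and the large boron-bearing group can go with no change that stands out from the scatter, so compound 2 and compound 3 cannot be told apart here. Nothing available explains this result.

On these data alone, whether a small methyl group or a plain benzyl group on this oxygen would read the same remains open. So does whether the boron atom itself matters at all.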